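The compounds below may be only part of what the source reports. "The series", "measured", "known", "first", "only" and "open" are said of these compounds alone.

Working notes on the series. The compounds share one core; compound 1 `Cn1c(=O)c(S(=O)(=O)c2ccc(Cl)cc2Cl)cc2cnc(Nc3ccc4[nH]ccc4c3)nc21` carries a 2,4-dichlorophenyl on its sulfonyl sulfur. Going by the values given here, in a functional assay on DU-145 cells (Homo sapiens) for inhibition, read by trypan blue exclusion, with a stated time of 72 h (on this read-out higher numbers stand for weaker inhibition and lower numbers for stronger inhibition), compound 1 gives 1000 nM, the lowest of the three numbers measured so far. Compound 2 `Cn1c(=O)c(S(=O)(=O)c2ccccc2)cc2cnc(Nc3ccc4ncccc4c3)nc21` gives 50000 nM in this assay, and compound 3 `Cn1c(=O)c(S(=O)(=O)c2ccc(F)cc2F)cc2cnc(NCc3ccc4[nH]ccc4c3)nc21` gives 100000 nM; both gaps to compound 1 lie beyond the scatter. Among the compounds with values here, no single-point step between measured compounds is available.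

Compound 4 `Cn1c(=O)c(S(=O)(=O)c2ccc(N)cc2F)cc2cnc(Nc3ccc4[nH]ccc4c3)nc21` differs from compound 1 in one place: 4-amino-2-fluorophenyl in place of 2,4-dichlorophenyl on a sulfonyl sulfur. Within the data shown here, with no measured step of this kind, only a small step in this assay is expected, toward a higher number or none beyond the scatter, giving a 2.0-fold higher number from compound 1 to compound 4 (0.30 log units; within the scatter). Compound 4 is therefore estimated at 2000 nM, with a range from 500 nM to 10000 nM.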

Compound 4, half-maximal inhibitory concentration: 8000 nM
For compound 4 the middle estimate is 4.0-fold (0.60 log units) below the measured one, within the range that was stated.
By their numbers in this assay, from the lowest: compound 1; then compound 4; then compounds 2 and 3 (each within the scatter of the next).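

In this assay, the group on the sulfonyl sulfur now has its first single-place reading: 4-amino-2-fluorophenyl in place of 2,4-dichlorophenyl gives an 8.0-fold higher number from compound 1 to compound 4 (0.90 log units; beyond the scatter). Compounds 2 and 3 could not show this, as each differs from compound 1 in more than one place. Nothing available accounts for the size of this step.

The step combines two substituent changes, so the separate contributions of the amino group and the fluorine remain unresolved. A 4-amino-2-chlorophenyl group on the core of compound 1 would separate them.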